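Cytotoxicity notes: urea for amide on the shared core

A few compounds are considered here, and "the series" means these few. Any claim that something is new, unique, unknown or untested is made for them only; others in the source may bear on it.

Measured so far in an ADME assay on C8166 cells (Homo sapiens) for cytotoxicity, read by MTT assay, with a stated time of 3 days; on this read-out higher numbers stand for lower toxicity in this test and lower numbers for higher toxicity in this test:
compound 1 `Cc1ccc(CNC(=O)c2nc(C(C)(C)NC(=O)OCc3ccccc3)nc(O)c2O)cc1`: 234000 nM
compound 2 `COc1ccc(CNC(=O)Nc2nc(C(C)(C)NC(=O)OCc3ccccc3)nc(O)c2O)cc1`: > 500000 nM
compound 3 `CC(C)(NC(=O)OCc1ccccc1)c1nc(O)c(O)c(C(=O)NCC2CC2)n1`: 204000 nM

Compound 2 reports only a limit in this assay, (the limit of > 500000 nM in this assay, at which 1 of the 3 values shown sits), and not a number. Among the two numbers shown, compound 3 sits lowest, with compound 1 nearest; the one measured step, a 1.1-fold lower number from compound 1 to compound 3 (0.06 log units; within the scatter), is within the scatter, so nothing separates these two.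

The next compound, compound 4 `COCCNC(=O)Nc1nc(C(C)(C)NC(=O)OCc2ccccc2)nc(O)c1O`, differs from compound 3 by ((2-methoxyethyl)carbamoyl)amino in place of (cyclopropylmethyl)carbamoyl on an aromatic carbon. Going by the values given here, the only measured step, from compound 1 to compound 3, changes a chain-end on the amide side and barely moves the read-out; it bears on the present step only loosely, since here the linkage itself changes to a urea-type group. Compound 2, which also carries a urea-type linkage on the shared core, gives a limit rather than a number. The step from compound 3 to compound 4 is therefore expected to be modest and, if anything, toward a higher number in this assay, a 1.7-fold higher number from compound 3 to compound 4 (0.23 log units; within the scatter), with a fair chance that only a limit is reported. Compound 4 is estimated at 350000 nM, between 150000 nM and 700000 nM.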

Compound 4, half-maximal cytotoxic concentration: > 500000 nM
Compound 4: a limit, no number; the forecaster's own chance of this, stated with the estimate: 35%; at least 1.4-fold (0.15 log units) between middle value and limit.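

In this assay, going by these compounds alone, this aromatic carbon gives the first steps that lie beyond the scatter: ((2-methoxyethyl)carbamoyl)amino in place of (cyclopropylmethyl)carbamoyl gives an at least 2.4-fold higher number from compound 3 to compound 4 (0.38 log units; beyond the scatter), and in place of (4-methylbenzyl)carbamoyl it gives an at least 2.1-fold higher number from compound 1 to compound 4 (0.32 log units; beyond the scatter). Compound 2 and compound 4, which both carry a urea-type linkage on the shared core, report a limit and not a number: the limit of > 500000 nM in this assay, at which 2 of the 4 values shown sit. The step between these two cannot be read, so the change from 4-methoxyphenyl to methoxymethyl on the urea side has no readable size.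

Both readable steps change the linkage and the chain end together, so they do not separate the two. Also open, from the compounds shown here alone, is whether a urea ending in an amine or a carboxylic acid would give a number or the same limit.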